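Swapping the five-membered ring for a six-membered one

The source may hold more compounds than are shown below. What is called first, only, known or untested is meant among the compounds shown, and "the series" means these compounds.

Measured compounds, with their solubility:
- compound 1, `Cn1nccc1-c1cc(C(F)(F)F)ccc1[C@H]1CCOc2cc(S(=O)(=O)Nc3ccncn3)ccc21`: 1180000 nM
- compound 2, `Cn1nccc1-c1cc(C(F)(F)F)ccc1[C@H]1CCc2cc(S(=O)(=O)Nc3ncccn3)ccc21`: 316000 nM
- compound 3, `O=S(=O)(Nc1ncccn1)c1ccc2c(c1)OCC[C@@H]2c1ccc(C(F)(F)F)cc1-c1ccc(F)nc1`: 408000 nM

In a physicochemical assay for solubility (on this read-out higher numbers stand for higher solubility and lower numbers for lower solubility), compound 2 gives 316000 nM, the lowest of the three numbers. Its nearest neighbour is compound 3, whose value in this assay is 408000 nM, a gap within the scatter, so the two cannot be ranked against each other. Compound 1, the most distant, gives 1180000 nM in this assay, a gap beyond the scatter.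

Compound 4, `Cc1ccc(-c2cc(C(F)(F)F)ccc2[C@H]2CCc3cc(S(=O)(=O)Nc4ncccn4)ccc32)cn1`, has not yet been measured. It differs from compound 2 in one place: 6-methylpyridin-3-yl in place of 1-methyl-1H-pyrazol-5-yl on an aromatic carbon. Going by the values given here, no step between two measured compounds corresponds to this change, so there is no measured template to lean on.

The group that enters carries more carbon and one fewer hydrogen-bond acceptor than the group that leaves. On that basis, the step from compound 2 to compound 4 in this assay is expected to be a modest drop, of a size at the edge of the scatter or a little beyond it, a 2.1-fold lower number from compound 2 to compound 4 (0.32 log units; beyond the scatter). Compound 4 is therefore expected to give about 150000 nM in this assay, with a range from 50000 nM to 400000 nM.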

Compound 4, solubility: 47000 nM
For compound 4 the middle estimate is 3.2-fold (0.50 log units) above the measured one, outside the stated range (below it).
By their numbers in this assay, from the lowest: compound 4; then compounds 2 and 3 (each within the scatter of the next); then compound 1.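

In this assay the aromatic carbon ortho to a large group and meta to a trifluoromethyl group proves sensitive to what it carries, as 6-methylpyridin-3-yl in place of 1-methyl-1H-pyrazol-5-yl gives a 6.7-fold lower number from compound 2 to compound 4 (0.83 log units; beyond the scatter) with nothing else in the structure altered. Going by these compounds alone, the earlier compounds offered no step between two measured partners, so this is the first direct reading of a change in one place, and it shows that the aromatic group at this carbon can by itself move the number beyond the scatter. The two groups differ at once in ring size, in heavy atoms and in hydrogen-bond acceptors, so this single step cannot assign the drop to any one of these differences.

Nothing available here accounts for the size of the step. Still open, on these data alone, is how a plain pyridin-3-yl without the methyl, a 1-methyl-1H-pyrazol-4-yl or a phenyl ring at this same carbon would compare, and each would help separate the influence of the methyl group, the ring nitrogens and the ring size.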